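Trimming the ether chain back to a methyl group

This account rests on a few compounds, and the source may have more. Where it says the series, first, only, none or still open, it means among the compounds named here.

Compound 1 `COc1cc([N+](=O)[O-])ccc1NS(C)(=O)=O`: > 25000 nM
Compound 2 `CCCOc1cc([N+](=O)[O-])ccc1N(C)S(C)(=O)=O`: 760 nM
Compound 3 `CN(c1ccc([N+](=O)[O-])cc1OCC1CCCCC1)S(C)(=O)=O`: 960 nM

The read-out throughout is an assay on SK-BR-3 cells for inhibition of Aromatase (Homo sapiens); on this read-out lower numbers stand for stronger inhibition and higher numbers for weaker inhibition. Compound 1 gives only a limit, (the limit of > 25000 nM in this assay, at which 1 of the 3 values shown sits), so no number stands for it. Compound 2 and compound 3 carry the two numbers; compound 3 sits at the higher one, though the step of a 1.3-fold higher number from compound 2 to compound 3 (0.10 log units; within the scatter) keeps the two within the scatter, so neither is called stronger or weaker.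

Compound 4 `COc1cc([N+](=O)[O-])ccc1N(C)S(C)(=O)=O` differs from compound 3 by hydrogen in place of cyclohexyl on a saturated chain carbon bound to an oxygen on an aromatic ring. Among the compounds with values here, no measured step shrinks the chain in this way. Within the data shown here, the one measured step, which enlarges the chain from compound 2 to compound 3, stayed within the scatter, so growing the group past propyl did not shift the number. Cutting it back to methyl is a different move; compound 1, which also carries a methyl here but lacks the methyl on nitrogen, reaches only a limit, and no step isolates the chain alone.

Compound 4 is therefore expected to give 3000 nM, between 800 nM and 15000 nM, a step of a 3.1-fold higher number from compound 3 to compound 4 (0.49 log units; beyond the scatter) estimated as a weakening that may or may not clear the scatter.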

Compound 4, half-maximal inhibitory concentration: > 25000 nM
Compound 4: no number, only a limit (the forecaster's own chance of this, stated with the estimate: 20%); at least 8.3-fold (0.92 log units) between middle value and limit.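

The change from cyclohexylmethyl to methyl gives an at least 26-fold higher number from compound 3 to compound 4 (1.41 log units; beyond the scatter), and the change from the propyl chain to methyl gives an at least 32-fold higher number from compound 2 to compound 4 (1.51 log units; beyond the scatter). The chain on this oxygen therefore does matter: the earlier step between the propyl and cyclohexylmethyl chains stayed within the scatter, which made the group look interchangeable, but that holds only for those two, and the methyl group of compound 4 does not share it. In this assay compound 4 gives only a limit and not a number, so these two steps mark a least size for the change, and its true size stays unknown: the limit of > 25000 nM in this assay, at which 2 of the 4 values shown sit.

On these data alone, the step from compound 1 to compound 4 cannot be read, as there is a limit on both sides, so what the methyl on the sulfonamide nitrogen contributes when the chain is a methyl group stays open. Also open, as far as these compounds go, is how short the chain can become before the number is lost, as an ethyl chain would test, and whether a chain ending in an amine or a carboxylic acid would keep the number seen with the propyl and cyclohexylmethyl chains.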